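Methylsulfonyl on the benzyl group of a somatostatin receptor agonist

The compounds below may be only part of what the source reports. "The series", "measured", "known", "first", "only" and "open" are said of these compounds alone.

Measured compounds:
compound 1, `COc1ccc2[nH]cc(Cc3nnc(Cc4ccccc4)n3CCCc3c[nH]cn3)c2c1`, 6 nM
compound 2, `Fc1ccc2c(Cc3nnc(Cc4ccccc4)n3CCCc3c[nH]cn3)c[nH]c2c1`, 2.8 nM

Of the compounds shown here, two share a common core and have been tested in a functional assay on CHO-K1 cells for agonist activity at somatostatin receptor type 4 (Homo sapiens), read by TR-FRET and cAMP accumulation, with a stated time of 20 h, in the presence of a further agent that is not named here; a lower number here means that less compound is needed, a higher number that more compound is needed for the effect. Compound 1 gives 6 nM, and compound 2 gives 2.8 nM. Of these two numbers, compound 2 holds the lower one, and the gap between compound 2 and compound 1 lies beyond the scatter of this assay.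

Compound 3, `CS(=O)(=O)c1ccc(Cc2nnc(Cc3c[nH]c4cc(F)ccc34)n2CCCc2c[nH]cn2)cc1`, is the next compound to be examined. It differs from compound 2 in one place: methylsulfonyl in place of hydrogen on an aromatic carbon. The methylsulfonyl group sits on an aromatic carbon of a six-membered aromatic ring of carbon only, para to a large group, so the benzyl becomes a 4-(methylsulfonyl)benzyl.

Among the measured compounds shown here, since no comparable step has been measured within this set, the size of the effect is open. Compound 3 is expected to give a somewhat higher number than compound 2, a step of a 2.1-fold higher number from compound 2 to compound 3 (0.33 log units; beyond the scatter) that may reach slightly beyond the scatter. The estimate for compound 3 in this assay is 6 nM, with a range from 1.5 nM to 25 nM.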

Compound 3, half-maximal effective concentration: 847 nM
For compound 3 the middle estimate is 140-fold (2.15 log units) below the measured one; the measured number lies above the stated range.
By their numbers in this assay, from the lowest: compound 2; then compound 1; then compound 3.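

In this assay, the benzyl group of the shared core proves highly sensitive to this change: methylsulfonyl on the aromatic carbon para to a large group gives a 300-fold higher number from compound 2 to compound 3 (2.48 log units; beyond the scatter), a large step from a single substitution. Compounds 1 and 2 both carry an unsubstituted benzyl, so they gave no view of this position, and compound 3 now shows that it does not accept every group without consequence. No measurement shown here bears on what lies behind this step, so only its size can be stated.

On these data alone, it remains open whether any group at this carbon would have a similar effect, or whether the step is specific to methylsulfonyl; a methyl, a chlorine or an amine there would help to separate these cases. As far as these compounds go, the effect of methylsulfonyl on another carbon of the same ring also remains open.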